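A few compounds are considered here, and "the series" means these few. Any claim that something is new, unique, unknown or untested is made for them only; others in the source may bear on it.

Compound 1 `COc1ccc2c(c1)c(-c1cc(C(F)(F)F)c(C#N)c(-c3cn(S(=O)(=O)c4ccc(C)cc4)c4ccc(OC)cc34)n1)cn2S(=O)(=O)c1ccc(C)cc1` and compound 2 `COc1ccc2c(-c3cc(C(F)(F)F)c(C#N)c(-c4cn(S(=O)(=O)c5ccc(C)cc5)c5cc(OC)ccc45)n3)cn(S(=O)(=O)c3ccc(C)cc3)c2c1` are built from the same atoms joined differently; how their two cores differ is not broken down here. In a functional assay on A549 cells (Homo sapiens) for inhibition, tested at 100 uM (a lower number here means a weaker effect, a higher number a stronger effect of the compound at the concentration tested), compound 1 gives 17.7%, while compound 2 gives 21.2%, and these two values lie within the scatter of each other. Compound 3 `COc1ccc2c(c1)c(-c1cc(C(F)(F)F)cc(-c3cn(S(=O)(=O)c4ccc(C)cc4)c4ccc(OC)cc34)n1)cn2S(=O)(=O)c1ccc(C)cc1` arises from compound 1 through (hydrogen in place of cyano on an aromatic carbon). In this assay compound 3 gives 41.7%, which is a number 24 percentage points higher from compound 1 to compound 3 (beyond the scatter), a change beyond the scatter, and the only measured example of this change among the compounds shown.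

Compound 4 `COc1ccc2c(-c3cc(C(F)(F)F)cc(-c4cn(S(=O)(=O)c5ccc(C)cc5)c5cc(OC)ccc45)n3)cn(S(=O)(=O)c3ccc(C)cc3)c2c1` stands to compound 2 as compound 3 stands to compound 1: it arises through (hydrogen in place of cyano on an aromatic carbon), the same change at a place described in the same words. Within the data shown here, since the only measured instance of this change is the one on the core of compound 1, the expectation for compound 4 rests on that single step and on the closeness of compound 1 and compound 2 in this assay. Among the measured compounds shown here, the step from compound 2 to compound 4 is expected to be a number 20.8 percentage points higher from compound 2 to compound 4 (beyond the scatter), set close to the measured step because a number 24 percentage points higher from compound 1 to compound 3 (beyond the scatter) is the one guide available. On that basis compound 4 is estimated to give 42% in this assay, with an expected range from 26% to 58%.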

Compound 4, a percentage reported as inhibition, at one concentration (the size of the read-out at that concentration, not a potency): 45.7%
Compound 4: the middle estimate sits 3.7 percentage points below what was measured; measured number inside the range.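

On the core of compound 2, hydrogen in place of cyano gives a number 24.5 percentage points higher from compound 2 to compound 4 (beyond the scatter) in this assay, and this step agrees with the one on the core of compound 1: the same change on two cores in this assay, a number 24 percentage points higher (beyond the scatter) from compound 1 to compound 3 and a number 24.5 percentage points higher (beyond the scatter) from compound 2 to compound 4, 0.5 percentage points apart, within the scatter of two such steps. Across these two cores, built from the same atoms joined differently, the change therefore carries over at about the same size, and the difference between the cores does not alter the step in this assay. Among these compounds, this rests on only two pairs, however, and on a read-out taken at a single concentration, so it shows neither that the step would hold on a core outside these two, nor how potency changes, nor why removing the nitrile raises the number.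

The compounds shown compare only cyano and hydrogen on this aromatic carbon, ortho to the trifluoromethyl group, so it remains open whether a methyl group, a chlorine atom, an amine or a carboxylic acid there would give a number nearer to that of hydrogen or of cyano. All four compounds also carry the same methylphenyl sulfonyl groups and the same trifluoromethyl group, which leaves open what an acetyl group in place of the sulfonyl groups, or a hydrogen in place of the trifluoromethyl group, would do in this series.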